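The compounds below may be only part of what the source reports. "The series", "measured", "known", "first", "only" and "open" are said of these compounds alone.

Measured so far:
- compound 1 `COc1ccc2cc(C(C)c3nnc4n3N=C(c3ccc([N+](=O)[O-])cc3)CS4)ccc2c1` — in a functional assay on MCF7 cells (Homo sapiens) for inhibition, read by sulforhodamine B assay, with a stated time of 72 h (a higher number here means a weaker inhibitor, a lower number a stronger inhibitor), compound 1 gives 18800 nM
- compound 2 `COc1ccc2cc(C(C)c3nnc4n3N=C(c3ccc(OC(F)(F)F)cc3)CS4)ccc2c1` — in this assay compound 2 gives 8800 nM

For the measured compounds named here, compound 2 holds the lower of the two numbers; its only neighbour is compound 1, and the step of a 2.1-fold lower number from compound 1 to compound 2 (0.33 log units; beyond the scatter) is a modest one, beyond the scatter.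

Compound 3 `COc1ccc2cc(C(C)c3nnc4n3N=C(c3ccc(Br)cc3)CS4)ccc2c1` is not yet measured. It differs from compound 2 in one place: bromo in place of trifluoromethoxy on an aromatic carbon.

Going by the values given here, the one measured step, a 2.1-fold lower number from compound 1 to compound 2 (0.33 log units; beyond the scatter), concerns the same place on the ring but a different pair of groups, so it bears on this change only loosely; no measured step exchanges bromo for trifluoromethoxy. With nothing pointing either way, the step of a 1.1-fold higher number from compound 2 to compound 3 (0.03 log units; within the scatter) is expected to stay within the scatter. Compound 3 is therefore estimated at 9500 nM in this assay, with a range from 3500 nM to 25000 nM.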

Compound 3, half-maximal inhibitory concentration: 11500 nM
Compound 3: the middle estimate sits 1.2-fold (0.08 log units) below what was measured; low and high end bracket the measured number.
By their numbers in this assay, from the lowest: compounds 2, 3 and 1 (each within the scatter of the next, the first and the last beyond it).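

In this assay, the change from 4-(trifluoromethoxy)phenyl to 4-bromophenyl gives a step that cannot be told apart from no change (a 1.3-fold higher number from compound 2 to compound 3 (0.12 log units; within the scatter)), so at this place on the ring bromo and trifluoromethoxy are not separated. Bromo is not separated from nitro either (a 1.6-fold lower number from compound 1 to compound 3 (0.21 log units; within the scatter)), which leaves compound 3 within the scatter of both neighbours, even though compound 1 and compound 2 themselves lie apart (a 2.1-fold lower number from compound 1 to compound 2 (0.33 log units; beyond the scatter)). Nothing at hand explains these numbers.

Open, as far as these compounds go, is whether a group of another kind at this place, such as an amine, a carboxylic acid or a plain hydrogen, would move the number beyond the scatter. Also open, from the compounds shown here alone, is how far changes elsewhere on the shared core, for instance at the methoxy group, would shift the number.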